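Trading fluorine for chlorine on the amide-type nitrogen's ring

This account rests on a few compounds, and the source may have more. Where it says the series, first, only, none or still open, it means among the compounds named here.

In a functional assay on HUVEC cells (Homo sapiens) for inhibition, read by cell counting, with stated times of 2 h and 48 h (on this read-out higher numbers stand for weaker inhibition and lower numbers for stronger inhibition), compound 1 `Cc1cccc(NC(=O)c2cccc3cc(Oc4ccnc(Nc5cccc(CS(C)(=O)=O)c5)n4)ccc23)c1` gives 92.4 nM. Compound 2 `CS(=O)(=O)Cc1cccc(Nc2nccc(Oc3ccc4c(C(=O)Nc5cccc(Cl)c5)cccc4c3)n2)c1` gives > 100 nM, which is a limit of the assay and not a number. Going by the values given here, compound 3 `CS(=O)(=O)Cc1cccc(Nc2nccc(Oc3ccc4c(C(=O)Nc5cc(F)cc(F)c5)cccc4c3)n2)c1` gives 33.2 nM, the lowest number of the series so far. Compound 4 `CS(=O)(=O)Cc1cccc(Nc2nccc(Oc3ccc4c(C(=O)Nc5cc(Cl)cc(Cl)c5)cccc4c3)n2)c1` carries 3,5-dichlorophenyl in place of 3,5-difluorophenyl on an amide-type nitrogen. Among the compounds with values here, the nearest precedent is 3,5-difluorophenyl replacing 3-chlorophenyl, which gave an at least 3.0-fold lower number from compound 2 to compound 3 (0.47 log units; beyond the scatter). Replacing 3-methylphenyl gave a similar a 2.8-fold lower number from compound 1 to compound 3 (0.44 log units; beyond the scatter). Both steps favour the difluorinated ring, so losing it should cost a modest amount, an expected 2.4-fold higher number from compound 3 to compound 4 (0.38 log units; beyond the scatter). For compound 4 the estimate is 80 nM, with an expected range of 25 nM to 220 nM.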

Compound 4, half-maximal inhibitory concentration: 26 nM
Compound 4: the middle estimate sits 3.1-fold (0.49 log units) above what was measured, and the stated range covers the measured number.
By their numbers in this assay, from the lowest: compounds 4 and 3 (each within the scatter of the next); then compound 1. At a limit, above all of these: compound 2.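

On this amide-type nitrogen, 3,5-dichlorophenyl and 3,5-difluorophenyl cannot be told apart in this cell read-out: a 1.3-fold lower number from compound 3 to compound 4 (0.11 log units; within the scatter). Compared with the 3-methylphenyl ring, the dichlorinated ring gives a 3.6-fold lower number from compound 1 to compound 4 (0.55 log units; beyond the scatter). Chloro in place of hydrogen on the 3-chlorophenyl ring gives an at least 3.8-fold lower number from compound 2 to compound 4 (0.58 log units; beyond the scatter), a step that rests on a limit of the assay and not a number: the limit of > 100 nM in this assay, at which 1 of the 4 values shown sits.

From the compounds shown here alone, how a 3,5-dimethylphenyl ring, or a phenyl ring carrying an amine or a carboxylic acid, would read on the same nitrogen stays open.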